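Adding a chlorine to the fused ring of compound 2

The source may hold more compounds than are shown below. What is called first, only, known or untested is meant among the compounds shown, and "the series" means these compounds.

Measured compounds and their values:
- compound 1 `COc1ccc(-n2ncn(Cc3cn(Cc4cc5cc(Br)ccc5nc4Cl)nn3)c2=O)cc1`: 333 ug/mL
- compound 2 `COc1ccc(-n2ncn(Cc3cn(Cc4cc5ccccc5nc4Cl)nn3)c2=O)cc1`: 958 ug/mL
- compound 3 `O=c1n(Cc2cn(Cc3cc4ccccc4nc3Cl)nn2)cnn1-c1ccccc1`: 655 ug/mL

These three compounds share one core and were tested in an ADME assay on HEK293 cells (Homo sapiens) for cytotoxicity, read by MTT assay; a lower number here means a stronger inhibitor, a higher number a weaker inhibitor. Compound 2 has the highest number of the three, yet compound 3 sits within the scatter of it, so the two cannot be told apart; only compound 1 is clearly separated, by a 2.9-fold higher number from compound 1 to compound 2 (0.46 log units; beyond the scatter).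

Compound 4 `COc1ccc(-n2ncn(Cc3cn(Cc4cc5ccc(Cl)cc5nc4Cl)nn3)c2=O)cc1` is not yet measured. It differs from compound 2 by chloro in place of hydrogen on an aromatic carbon. Within the data shown here, the one measured step that bears on this is the removal of bromo from compound 1 to give compound 2, which raised the number by a 2.9-fold higher number from compound 1 to compound 2 (0.46 log units; beyond the scatter). Putting a halogen back onto the same fused ring, here chloro, is expected to move the number the other way, by a modest amount. The step from compound 2 to compound 4 is therefore expected to be about a 2.1-fold lower number from compound 2 to compound 4 (0.33 log units; beyond the scatter). Compound 4 is estimated to give 450 ug/mL in this assay, within a range from 200 ug/mL to 950 ug/mL.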

Compound 4, half-maximal inhibitory concentration: 1470 ug/mL
Beside the measured number, compound 4's estimate is 3.3-fold (0.51 log units) below it, outside the stated range (above it).
By their numbers in this assay, from the lowest: compounds 1, 3, 2 and 4 (each within the scatter of the next, the first and the last beyond it).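

In this assay chloro in place of hydrogen on this aromatic carbon of the fused system gives a 1.5-fold higher number from compound 2 to compound 4 (0.19 log units; within the scatter) and so leaves no readable difference at this position. The earlier bromo step, a 2.9-fold higher number from compound 1 to compound 2 (0.46 log units; beyond the scatter) and beyond the scatter, might have suggested that a halogen on this fused system lowers the number, but compound 4 goes against that pattern, which now rests on compound 1 alone. No measurement at hand explains the contrast between these two halogen steps.

The compounds shown leave open whether the contrast comes from the kind of halogen or from the carbon that carries it, since bromo and chloro are not compared on one carbon. They also leave open how a different group on this carbon, such as an amine or a carboxylic acid, would read in this assay against the hydrogen of compound 2.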